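Acetamido to propanoylamino applied a second time in the series

The compounds below may be only part of what the source reports. "The series", "measured", "known", "first", "only" and "open" are said of these compounds alone.

Measured compounds, with their values in an assay for binding affinity to melatonin receptor (Gallus gallus); a lower number here means a stronger inhibitor, a higher number a weaker inhibitor:
compound 1, `COc1ccc(CCCNC(C)=O)cc1`, 14000 nM
compound 2, `CCC(=O)NCCCc1ccc(OC)cc1`, 2900 nM
compound 3, `CC(=O)NCCCc1cccc(Br)c1`, 852 nM

Compound 1 and compound 2 share one core and differ only by methyl in place of hydrogen on a saturated chain carbon bound to a carbonyl carbon. Within this pair, the change gave a 4.8-fold lower number from compound 1 to compound 2 (0.68 log units; beyond the scatter). Compound 3 carries a different core; the difference between the two cores is not broken down here. Compound 3 gives the lowest of the three numbers in this assay, and its gap to each of the other two is beyond the scatter.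

Compound 4, `CCC(=O)NCCCc1cccc(Br)c1`, is not yet measured. It differs from compound 3 by methyl in place of hydrogen on a saturated chain carbon bound to a carbonyl carbon, and the place of the change reads the same, word for word, as in the step from compound 1 to compound 2, so this is the same change set on the second core. Among the measured compounds shown here, the expectation for compound 4 rests on the single earlier example, namely the step from compound 1 to compound 2, which is beyond the scatter and is the only step measured for this change. On that basis the step from compound 3 to compound 4 in this assay is expected to be about a 4.3-fold lower number from compound 3 to compound 4 (0.63 log units; beyond the scatter). For the measured compounds named here, compound 4 is accordingly estimated at 200 nM, with a range from 80 nM to 500 nM, the range being wide because only one earlier step, a 4.8-fold lower number from compound 1 to compound 2 (0.68 log units; beyond the scatter), supports the transfer to a second core.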

Compound 4, inhibition constant: 318 nM
The estimate for compound 4 lay 1.6-fold (0.20 log units) below the measured number; low and high end bracket the measured number.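

On the core of compound 3, the change from acetamido to propanoylamino again moves the read-out in this assay in the same direction as on the core of compound 1. The new step is a 2.7-fold lower number from compound 3 to compound 4 (0.43 log units; beyond the scatter) and adds a second example to the single one available before. The two steps point the same way, and their sizes cannot be told apart: the same change on two cores in this assay, a 4.8-fold lower number (0.68 log units; beyond the scatter) from compound 1 to compound 2 and a 2.7-fold lower number (0.43 log units; beyond the scatter) from compound 3 to compound 4, 1.8-fold (0.26 log units) apart, within the scatter of two such steps. This supports carrying the change between these two cores in this one assay, but two cores are a thin base, so it does not show that the step would hold on any further core, nor does it explain why the number falls.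

Still open, on these data alone, is whether the trend continues along the acyl chain, for instance with butanoyl or a longer chain in place of propanoyl, or whether it survives branching, as with isobutanoyl, or a small ring, as with cyclopropanecarbonyl. Also open, as far as these compounds go, is whether a urea or a carbamate in place of the amide would follow the same course on either core, and whether the step would look the same in an assay on the melatonin receptor of another species.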